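Working notes: bromo to acetamido on the aryl sulfonyl group

The compounds below may be only part of what the source reports. "The series", "measured", "known", "first", "only" and "open" are said of these compounds alone.

Values in an ADME assay on L02 cells (Homo sapiens) for cytotoxicity, read by MTT assay, with a stated time of 24 h; on this read-out lower numbers stand for stronger inhibition and higher numbers for weaker inhibition:
- Compound 1 `Cc1ccc(S(=O)(=O)N2C/C(=C\c3cccnc3)C(=O)/C(=C/c3ccccc3F)C2)cc1` gives 14900 nM
- Compound 2 `O=C1/C(=C/c2cccnc2)CN(S(=O)(=O)c2ccc(C(F)(F)F)cc2)C/C1=C\c1ccccc1F` gives 11300 nM
- Compound 3 `O=C1/C(=C/c2cccnc2)CN(S(=O)(=O)c2ccc(Br)cc2)C/C1=C\c1ccccc1F` gives 14600 nM

Compound 3 lies within the scatter of both other compounds, so these three values form one level. Compound 4 `CC(=O)Nc1ccc(S(=O)(=O)N2C/C(=C\c3cccnc3)C(=O)/C(=C/c3ccccc3F)C2)cc1` differs from compound 3 by acetamido in place of bromo on an aromatic carbon in this place, acetamido in place of bromo on an aromatic carbon. Three measured steps at that carbon bear on it: a 1.3-fold lower number from compound 1 to compound 2 (0.12 log units; within the scatter) and a 1.0-fold lower number from compound 1 to compound 3 (0.01 log units; within the scatter) and a 1.3-fold higher number from compound 2 to compound 3 (0.11 log units; within the scatter) are all small. Acetamido itself is untested here, so these steps cover the change only loosely. The expected 1.1-fold higher number from compound 3 to compound 4 (0.04 log units; within the scatter) gives no step beyond the scatter in either direction. Compound 4 is estimated at 16000 nM in this assay with an expected range of 8000 nM to 32000 nM for repeated measurements.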

Compound 4, half-maximal inhibitory concentration: 15600 nM
For compound 4 the middle estimate is 1.0-fold (0.01 log units) above the measured one; low and high end bracket the measured number.
By their numbers in this assay, from the lowest: compounds 2, 3, 1 and 4 (each within the scatter of the next).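

In this assay acetamido, with its hydrogen-bond donor and acceptor, gives a 1.1-fold higher number from compound 3 to compound 4 (0.03 log units; within the scatter) and a 1.4-fold higher number from compound 2 to compound 4 (0.14 log units; within the scatter) and a 1.0-fold higher number from compound 1 to compound 4 (0.02 log units; within the scatter) at this aromatic carbon para to a large group. Adding a hydrogen-bond donor and acceptor at this carbon thus produces no step beyond the scatter, and all four compounds remain one level. Nothing available explains this flat result.

On these data alone, whether an amine or a carboxylic acid at this carbon would stay at the same level remains open. The same holds for changes elsewhere on the shared core.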